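From compound 2 to compound 3: a chloro is added

The compounds below may be only part of what the source reports. "The series", "measured", "known", "first", "only" and "open" are said of these compounds alone.

In a physicochemical assay for lipophilicity, at pH 7.4 (a higher number here means a more lipophilic compound, a lower number a more polar compound), compound 1 `O=c1[nH]c(Oc2ccccc2)nc2cnccc12` gives 1.2. Within the data shown here, compound 2 `O=c1[nH]c(Oc2cccc(O)c2)nc2cnccc12` has a hydroxy in place of hydrogen on an aromatic carbon and gives 0.3, the lower of the two numbers so far. The measured change is a number 0.90 log units lower from compound 1 to compound 2 (beyond the scatter).

Compound 3 `O=c1[nH]c(Oc2ccc(Cl)c(O)c2)nc2cnccc12` keeps that hydroxy and gains a chloro in place of hydrogen on an aromatic carbon, ortho to the hydroxy group and para to a large group: chloro in place of hydrogen on an aromatic carbon.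

Among the measured compounds shown here, only one measured step is available, and it brings in a hydroxy, not a chloro. It therefore bears on this change only indirectly, by showing how far one substitution on an aromatic carbon can move the number in this series. For the measured compounds named here, no measured pair shows a chloro entering, so the upward direction expected here is a judgement from the structural change alone. The size is expected to be similar to that one step, and the estimated change is a number 0.70 log units higher from compound 2 to compound 3 (beyond the scatter). For compound 3 the expected value in this assay is 1, with an estimated range of 0.5 to 1.5.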

Compound 3, distribution coefficient: 1.1
The estimate for compound 3 lay 0.10 log units below the measured number, within the range that was stated.
By their numbers in this assay, from the lowest: compound 2; then compounds 3 and 1 (each within the scatter of the next).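

In this assay, among these compounds, the chloro gives a number 0.80 log units higher from compound 2 to compound 3 (beyond the scatter), the first measured step in which the number goes up, and it is large enough to count as a real change rather than repeat-measurement noise. The earlier substitution on the same aromatic ring, the hydroxy, gave a number 0.90 log units lower from compound 1 to compound 2 (beyond the scatter), so single substitutions on this ring have now been seen to move the number in both directions, and the hydroxy is still present in compound 3 when the number rises. Nothing measured here explains why the chloro shifts the number in this way.

As far as these compounds go, what a different group would do on this same aromatic carbon, ortho to the hydroxy group and para to a large group, remains open: a fluoro, a methyl or a methoxy might move the number further, less far or the opposite way. From the compounds shown here alone, it is also open whether a chloro would produce a step of this size on compound 1, where no hydroxy is present, or on a compound carrying an amine in place of the hydroxy.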